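A Smaller Ring on the More Stable Compound

The compounds below may be only part of what the source reports. "The series", "measured", "known", "first", "only" and "open" are said of these compounds alone.

Within the data shown here, in an ADME assay on microsomes from liver (Rattus norvegicus) for metabolic stability, with a stated time of 30 min, tested at 1 uM (on this read-out higher numbers stand for a more stable compound and lower numbers for a less stable compound), compound 2 `CC[C@@H]1C(=O)N(C)c2cnc(-n3ccnc3-c3ccc(F)cc3)nc2N1[C@H]1CCOC1` gives 67% as the higher of the two numbers so far, while compound 1 `CC[C@@H]1C(=O)N(C)c2cnc(-c3cn[nH]c3-c3ccc(F)cc3F)nc2N1c1cnn(C)c1` stands lower at 13%. This gap lies beyond the usual scatter. Compound 3 `CC[C@@H]1C(=O)N(C)c2cnc(-n3ccnc3-c3ccc(F)cc3)nc2N1C1COC1` differs from compound 2 by oxetan-3-yl in place of oxolan-3-yl on a nitrogen on an aromatic ring in a ring and carries oxetan-3-yl in place of oxolan-3-yl on a nitrogen on an aromatic ring in a ring. Among the measured compounds shown here, compound 1 and compound 2 differ in several places, and no measured pair shows this change alone. A small rise is expected, with the step of a number 5 percentage points higher from compound 2 to compound 3 (within the scatter) not beyond the scatter. For compound 3 the estimated value is 72% in an expected range from 55% to 88% on this read-out.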

Compound 3, percent of the compound remaining: 80%
Compound 3: middle estimate off by 8 percentage points, on the low side; the range from low to high includes it.
By their numbers in this assay, from the lowest: compound 1; then compound 2; then compound 3.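

Among these compounds, changing oxolan-3-yl to oxetan-3-yl on this nitrogen gives the first single-place comparison in this assay, and the number moves a number 13 percentage points higher from compound 2 to compound 3 (beyond the scatter) as a modest step. This shows that the position responds to the change, with the four-membered ring giving the more stable compound of this pair. The change also removes a defined stereocentre, so ring size and that stereocentre cannot be separated, and nothing measured here explains the rise.

Going by these compounds, whether an open chain such as methoxyethyl or an amine such as piperidin-4-yl would fare as well on this nitrogen remains open. So does whether the same ring change would give a similar step on another core.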